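The source may hold more compounds than are shown below. What is called first, only, known or untested is meant among the compounds shown, and "the series" means these compounds.

Measured in a functional assay on HepG2 cells (Homo sapiens) for inhibition, read by MTT assay, with a stated time of 72 h, tested at 30 uM; a lower number here means less inhibition of growth, a higher number more inhibition of growth at the concentration tested:
- compound 1 `C=CCc1cc(O)c(O)c(CN2CCC(CCO)CC2)c1`: 2.5%
- compound 2 `C#CCOc1ccc(CC=C)cc1O`: 1.5%

Compound 1 and compound 2 lie within the usual scatter of each other, and both show little growth inhibition. Compound 3 `C=CCc1cc(O)c(O)c(CN2CCC(Cc3ccccc3)CC2)c1` keeps the core of compound 1 but has phenyl in place of hydroxymethyl on a saturated chain carbon bound to a saturated ring carbon. Within the data shown here, no measured pair shows what such a change does, so any expectation is loose. The expected step of a number 11.5 percentage points higher from compound 1 to compound 3 (beyond the scatter) is a modest rise in this assay, just beyond the scatter. For compound 3 the estimate is 14%, with an expected range of 2% to 40%.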

Compound 3, percent growth inhibition at one concentration: 70.2%
Estimate against measurement, compound 3: 56.2 percentage points below; the measured number lies above the stated range.
By their numbers in this assay, from the lowest: compounds 2 and 1 (each within the scatter of the next); then compound 3.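

Growth inhibition in this assay responds strongly to what sits on a saturated chain carbon bound to a saturated ring carbon: phenyl in place of hydroxymethyl gives a large rise (a number 67.7 percentage points higher from compound 1 to compound 3 (beyond the scatter)). The core of compound 1 therefore does not fix the result by itself, and this position can change it greatly. Nothing shown explains the size of this step. Going by these compounds, it remains open whether the aromatic ring is needed, or whether a cyclohexyl group, an amine or a longer chain at this place would give a similar result.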